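A few compounds are considered here, and "the series" means these few. Any claim that something is new, unique, unknown or untested is made for them only; others in the source may bear on it.

In a functional assay on SK-BR-3 cells (Homo sapiens) for antiproliferative activity (on this read-out higher numbers stand for weaker inhibition and lower numbers for stronger inhibition), compound 1 (`C#CCOc1ccc(C(=O)Nc2cc3ccc(OC4CCN(C)CC4)c(C)c3oc2=O)cc1CC=C(C)C`) gives 1400 nM while compound 2 (`Cc1c(OC2CCN(C)CC2)ccc2cc(NC(=O)c3ccc(O)c(CCC(C)C)c3)c(=O)oc12`) gives 600 nM and compound 3 (`C=CCc1cc(C(=O)Nc2cc3ccc(OC4CCN(C)CC4)c(C)c3oc2=O)ccc1OC(C)=O`) gives 2260 nM on the same read-out. Compound 2 has the lowest number of the three, and its gaps to both others lie beyond the scatter. Compound 4 (`COc1cccc(-c2cc(C(=O)Nc3cc4ccc(OC5CCN(C)CC5)c(C)c4oc3=O)ccc2O)c1`) keeps the shared core of compound 2 but carries 3-methoxyphenyl in place of isopentyl on an aromatic carbon, ortho to a hydroxy group (3-methoxyphenyl in place of isopentyl on an aromatic carbon). Going by the values given here, no measured pair differs in just one place, so nothing here shows directly what such a swap does. The expected step is therefore small and stays within the scatter (a 1.2-fold lower number from compound 2 to compound 4 (0.08 log units; within the scatter)). For compound 4 the estimated value is 500 nM with an expected range from 150 nM to 1700 nM in this measurement.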

Compound 4, half-maximal inhibitory concentration: 860 nM
Beside the measured number, compound 4's estimate is 1.7-fold (0.24 log units) below it; low and high end bracket the measured number.
By their numbers in this assay, from the lowest: compounds 2, 4, 1 and 3 (each within the scatter of the next, the first and the last beyond it).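

Going by these compounds alone, compound 2 and compound 4 form the first pair here that differs in only one place. In this assay, placing 3-methoxyphenyl in place of isopentyl on an aromatic carbon, ortho to a hydroxy group, gives a 1.4-fold higher number from compound 2 to compound 4 (0.16 log units; within the scatter), so at this position a ring-free chain and an aromatic ring read alike on this assay. Nothing measured here explains why the two groups read alike.

On these data alone, what an amine, a carboxylic acid or a longer chain would do at this position stays open. As far as these compounds go, it is also open whether 3-methoxyphenyl would read the same with the hydroxy group replaced by methoxy.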